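A few compounds are considered here, and "the series" means these few. Any claim that something is new, unique, unknown or untested is made for them only; others in the source may bear on it.

Measured compounds and their values:

- compound 1, `CCC(C)(C)Cc1c[nH]c(CCc2ccc(-c3ccncc3)cc2)n1`: 305 nM
- compound 2, `c1ccc(-c2ccc(CCc3nc(CC4CCCC4)c[nH]3)cc2)nc1`: 425 nM
- compound 3, `CCC(C)(C)Cc1c[nH]c(CCc2ccc(-c3cnccn3)cc2)n1`: 431 nM

All three were tested in a functional assay on HEK293 cells for agonist activity at Bombesin receptor subtype-3 (Homo sapiens), read by luminescence and calcium flux, with a stated time of 10 min; a lower number here means that less compound is needed, a higher number that more compound is needed for the effect. Compound 3 gives the highest of the three numbers, but its distance to compound 2 and to compound 1 lies within the scatter, so no order among the three can be claimed. Within the data shown here, the one step that can be followed, a 1.4-fold higher number from compound 1 to compound 3 (0.15 log units; within the scatter), shows that swapping one six-membered aromatic ring with two nitrogens for another left the number essentially unchanged.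

Compound 4, `CCC(C)(C)Cc1c[nH]c(CCc2ccc(N3CCCCC3)cc2)n1`, has not yet been measured. Compared with compound 3 it differs as follows: piperidin-1-yl in place of pyrazin-2-yl on an aromatic carbon

Among the measured compounds shown here, no measured step bears directly on this change: the only step available, from compound 1 to compound 3, exchanged one aromatic ring for another, whereas here an aromatic ring gives way to a non-aromatic one attached through its nitrogen. That step was within the scatter, but it offers no guide to the new kind of change, so the expectation is wide. Compound 4 is expected to give 700 nM, with a range from 150 nM to 3000 nM; this means an expected step of a 1.6-fold higher number from compound 3 to compound 4 (0.21 log units; within the scatter).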

Compound 4, half-maximal effective concentration: 171 nM
Compound 4: the middle estimate sits 4.1-fold (0.61 log units) above what was measured; measured number inside the range.
By their numbers in this assay, from the lowest: compounds 4, 1, 2 and 3 (each within the scatter of the next, the first and the last beyond it).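

In this assay, among these compounds, the position on an aromatic carbon, para to a large group, turns out not to need an aromatic ring: putting piperidin-1-yl in place of pyrazin-2-yl gives a 2.5-fold lower number from compound 3 to compound 4 (0.40 log units; beyond the scatter), a modest but real change, whereas the earlier compounds carried only aromatic rings here and their one step stayed within the scatter. The comparison with pyridin-4-yl is less clear, as a 1.8-fold lower number from compound 1 to compound 4 (0.25 log units; within the scatter) does not separate these two groups, so the advantage of piperidin-1-yl holds only against pyrazin-2-yl. No measurement shown here explains why the non-aromatic ring does better than pyrazin-2-yl.

As far as these compounds go, it remains open whether the ring nitrogen and its point of attachment matter, which piperidin-4-yl, joined through a carbon, or cyclohexyl, with no ring nitrogen, could help to settle. Also unresolved is whether a ring is needed at all, a question that an open-chain group such as diethylamino could address, and how a ring with an added oxygen, such as morpholin-4-yl, would compare.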